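The source may report more compounds than this note shows. Statements on the series, on what has been measured and on what is new or still open speak of the compounds shown alone.

Measured compounds:
compound 1 `C[C@@]1(c2ccccc2F)CCOC(N)=N1` — 9.8
compound 2 `CC1=C[C@@](C)(c2cc(NC(=O)c3ccc(C#N)cn3)ccc2F)N=C(N)O1` — 7.9

In a physicochemical assay for acid dissociation, read by capillary electrophoresis, compound 2 stands lowest of the two numbers; its nearest neighbour is compound 1, whose reading lies higher by a gap beyond the usual scatter.

Compound 3 `C[C@@]1(c2cc(NC(=O)c3ccc(C#N)cn3)ccc2F)C=COC(N)=N1` is not yet measured in this assay. Relative to compound 2 it carries the change (hydrogen in place of methyl on a double-bonded ring carbon). Going by the values given here, no step between measured compounds isolates this change, so it is judged only from the reading of compound 2. The expectation is a small downward step, a number 0.20 log units lower from compound 2 to compound 3 (within the scatter), likely within the scatter. Compound 3 is therefore estimated at 7.7, in the range 7.2 to 8.2.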

Compound 3, acid dissociation constant: 7.7
Estimate against measurement, compound 3: no gap at the digits printed, within the range that was stated.
By their numbers in this assay, from the lowest: compounds 3 and 2 (each within the scatter of the next); then compound 1.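

In this assay, going by these compounds alone, the first look at this position gives a number 0.20 log units lower from compound 2 to compound 3 (within the scatter), so compound 3 and compound 2 cannot be told apart. Hydrogen in place of methyl on a double-bonded ring carbon, next to the ring oxygen, thus leaves this read-out without a resolved shift, which compound 1, differing in more than one place, could not show.

Still open, from the compounds shown here alone, is whether an ethyl chain, a methoxy group or an amine on this carbon would give a step beyond the scatter. Also open, going by these compounds, is whether the step holds without the nitrile-bearing amide. Nothing at hand bears on a cause for this result.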